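Fluoro in place of trifluoromethoxy: working notes

The compounds below may be only part of what the source reports. "The series", "measured", "known", "first", "only" and "open" are said of these compounds alone.

In an ADME assay on BJ cells (Homo sapiens) for cytotoxicity, read by luminescence, with a stated time of 72 h (a lower number here means that less compound is needed, a higher number that more compound is needed for the effect), compound 1 (`CCOC(=O)c1c(-c2cccc(F)c2)[nH]c2cc(OC)ccc2c1=O`) gives > 21500 nM as a limit and not a number. Compound 2 (`CCOC(=O)c1c(-c2cccc(OC(F)(F)F)c2)[nH]c2cc(OC)c(F)cc2c1=O`) gives > 21500 nM as a limit and not a number. Within the data shown here, compound 2 therefore has no numeric value to stand on, and the one other value shown is also a limit; the record so far is the limit of > 21500 nM in this assay, at which 2 of the 2 values shown sit, and nothing finer.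

Compound 3 (`CCOC(=O)c1c(-c2cccc(F)c2)[nH]c2cc(OC)c(F)cc2c1=O`) carries fluoro in place of trifluoromethoxy on an aromatic carbon, meta to a large group (fluoro in place of trifluoromethoxy on an aromatic carbon). Among the measured compounds shown here, no step between measured compounds is available to size this change. An expected step that the limit leaves unreadable from compound 2 to compound 3 stays within the scatter, with no shift in either direction anticipated in this assay for this change. For compound 3 the estimated value is 22000 nM with an expected range of 12000 nM to 40000 nM and a report only as a limit is likely.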

Compound 3, half-maximal effective concentration: > 21500 nM
Compound 3: no number, only a limit; the forecaster's own chance of this, stated with the estimate: 85%; the middle value lies beyond the limit too.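

Neither step into compound 3, from compound 1 or from compound 2, can be read, because all three compounds give only a limit and not a number: the limit of > 21500 nM in this assay, at which 3 of the 3 values shown sit.

The compounds shown leave open whether fluoro in place of trifluoromethoxy or fluoro in place of hydrogen on an aromatic carbon shifts the half-maximal effective concentration in this assay at all.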